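Swapping an ester tether for a longer ether chain

The compounds below may be only part of what the source reports. "The series", "measured", "known", "first", "only" and "open" are said of these compounds alone.

Two selenocyanate-bearing compounds built on a shared core have been measured in a functional assay on MDA-MB-231 cells (Homo sapiens) for inhibition, read by MTT assay, with a stated time of 48 h; on this read-out higher numbers stand for weaker inhibition and lower numbers for stronger inhibition. Compound 1 `COc1ccc(N(C)c2nc(C)nc3ccccc23)cc1C(=O)OCC[Se]C#N` gives 1480 nM, the highest of the two numbers recorded. Compound 2 `CN(c1ccc([Se]C#N)cc1)c1nc(C2CC2)nc2ccccc12`, which carries its selenocyanate directly on the ring and a cyclopropyl group in place of methyl, gives 29 nM; the gap between these two values lies well beyond the usual scatter, so compound 1 is the weaker inhibitor here.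

Compound 3 `COc1ccc(N(C)c2nc(C)nc3ccccc23)cc1OCCCCC[Se]C#N` has not been measured. It differs from compound 1 in one place: a group of 9 heavy atoms (6 carbon, 1 nitrogen, 1 oxygen, 1 selenium; no ring) in place of a group of 8 heavy atoms (4 carbon, 1 nitrogen, 2 oxygen, 1 selenium; no ring), on an aromatic carbon. Among the compounds with values here, no step between measured compounds matches this change, so no direct guide exists. The expectation is a step from compound 1 to compound 3 of about a 1.5-fold lower number from compound 1 to compound 3 (0.17 log units; within the scatter), essentially none beyond the scatter. Compound 3 is therefore expected to give roughly 1000 nM, with a plausible range from 300 nM to 3500 nM.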

Compound 3, half-maximal inhibitory concentration: 4410 nM
The estimate for compound 3 lay 4.4-fold (0.64 log units) below the measured number; the measured number lies above the stated range.
By their numbers in this assay, from the lowest: compound 2; then compound 1; then compound 3.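

In this assay, replacing the ester tether on this aromatic carbon, ortho to a methoxy group, with the longer ether chain gives a 3.0-fold higher number from compound 1 to compound 3 (0.47 log units; beyond the scatter), a modest but real loss of inhibition. This shows that the link carrying the selenocyanate at this position can change the read-out, and that a similar-sized chain does not guarantee a similar result. The change removes the carbonyl and alters the chain length together, and no measurement here accounts for the loss.

On these data alone, it remains open whether the step follows from the change of link or from the change of length; a shorter ether chain or an amide tether would help separate the two. Also open, as far as these compounds go, is how a thiocyanate in place of the selenocyanate would read at this position.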